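Trifluorophenyl for methylphenyl on a high-clearance sulfonamide

The source may hold more compounds than are shown below. What is called first, only, known or untested is meant among the compounds shown, and "the series" means these compounds.

Measured in an ADME assay (liver) for metabolic stability, with Liver microsome (Homo sapiens) as the target, read by LC-MS, using microsomes and NADPH, with a stated time of 5 min, at 37 degrees C; a higher number here means faster removal of the compound, a lower number slower removal:
- compound 1 `CCn1c([C@@H](C)NS(=O)(=O)c2ccc(Cl)cc2)nc2cc(F)c(Cl)cc21`: > 100 mL.min-1.g-1 (a limit)
- compound 2 `CCn1c([C@@H](C)NS(=O)(=O)c2ccc(Cl)cc2)nc2cc(C(N)=O)ccc21`: < 5 mL.min-1.g-1 (a limit)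
- compound 3 `CCn1c([C@@H](C)NS(=O)(=O)c2ccc(C)cc2)nc2ccc(C(F)(F)F)cc21`: > 100 mL.min-1.g-1 (a limit)

All three results are limits of the assay rather than numbers. Compound 3 stands at the limit of > 100 mL.min-1.g-1 in this assay, at which 2 of the 3 values shown sit. Compound 2 stands at the limit of < 5 mL.min-1.g-1 in this assay, at which 1 of the 3 values shown sits.

The next compound, compound 4 `CCn1c([C@@H](C)NS(=O)(=O)c2c(F)cc(F)cc2F)nc2ccc(C(F)(F)F)cc21`, carries 2,4,6-trifluorophenyl in place of 4-methylphenyl on a sulfonyl sulfur. For the measured compounds named here, no measured pair isolates this change, and the starting point is itself a limit, so any forecast in this assay is loose. A moderate fall in clearance is expected, though a second result at the upper limit remains quite possible. The expected change is estimated as an at least 1.6-fold lower number from compound 3 to compound 4 (0.22 log units; that floor lies within the scatter). For compound 4 the estimated value is 60 mL.min-1.g-1, with an expected range of 20 mL.min-1.g-1 to 100 mL.min-1.g-1.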

Compound 4, intrinsic clearance in microsomes: 19 mL.min-1.g-1
Compound 4: middle estimate off by 3.2-fold (0.50 log units), on the high side; the measured number lies below the stated range.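

In this assay, 2,4,6-trifluorophenyl in place of 4-methylphenyl on a sulfonyl sulfur gives an at least 5.2-fold lower number from compound 3 to compound 4 (0.72 log units; beyond the scatter). This brings the series its first true number rather than a limit, showing that the group on the sulfonyl sulfur can by itself bring a compound off the upper limit with the rest of the structure unchanged. Compound 3 sits at a limit, so the step is a floor and its full size cannot be read: the limit of > 100 mL.min-1.g-1 in this assay, at which 2 of the 4 values shown sit.

The compounds shown do not separate the loss of the methyl from the entry of the three fluorines, nor does any one of the fluorines stand out. An unsubstituted phenyl, a 4-fluorophenyl or a pyridine ring on the sulfonyl sulfur would divide the step into its parts.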